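From Phenyl to 1H-Pyrrol-2-yl: an Expected Value

A few compounds are considered here, and "the series" means these few. Any claim that something is new, unique, unknown or untested is made for them only; others in the source may bear on it.

Measured so far in a functional assay on A-375 cells (Homo sapiens) for activation, with a stated time of 3 days; a lower number here means that less compound is needed, a higher number that more compound is needed for the effect:
Compound 1 `O=C(Nc1ccc(-c2cscn2)cc1)C1CCCN(Cc2ccc(F)cc2)C1` gives 5000 nM.
Compound 3 `O=C(Nc1ccc(-c2ccccc2)cc1)C1CCCN(Cc2ccc(F)c(F)c2)C1` gives 5000 nM.
Compound 2 `O=C(Nc1ccc(-c2cscn2)cc1)C1CCCN(Cc2cccc(C(F)(F)F)c2)C1` gives only a limit of the assay, > 20000 nM.

Compound 3 stands level with compound 1 at the digits shown, within the scatter. The two differ in two places, so their values show only that they match. Compound 4 `O=C(Nc1ccc(-c2ccc[nH]2)cc1)C1CCCN(Cc2ccc(F)c(F)c2)C1` differs from compound 3 in one place: 1H-pyrrol-2-yl in place of phenyl on an aromatic carbon. Among the measured compounds shown here, the single measured step, an at least 4.0-fold higher number from compound 1 to compound 2 (0.60 log units; beyond the scatter), alters a different part of the molecule and so does not bear on this exchange. For the measured compounds named here, with no step to guide the direction, compound 4 is expected to remain about level, the step of no change at the digits printed from compound 3 to compound 4 (within the scatter) being the estimate. Compound 4 is therefore estimated at 5000 nM, in the range 1500 nM to 16000 nM.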

Compound 4, half-maximal effective concentration: 720 nM
For compound 4 the middle estimate is 6.9-fold (0.84 log units) above the measured one; the measured number lies below the stated range.
By their numbers in this assay, from the lowest: compound 4; then compounds 1 and 3 (each within the scatter of the next). At a limit, above all of these: compound 2.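

This position on the aromatic ring responds to change: in this assay, 1H-pyrrol-2-yl in place of phenyl gives a 6.9-fold lower number from compound 3 to compound 4 (0.84 log units; beyond the scatter). Compounds 1 and 3 differ in two places, so their matching values could not show this. No measurement shown bears on why the number falls.

The compounds shown leave open how 1-methylpyrrol-2-yl or furan-2-yl would read here, and so whether the hydrogen-bond donor of 1H-pyrrol-2-yl plays any part.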